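Compound 3 to compound 4: a methylcarbamoyl swap

A few compounds are considered here, and "the series" means these few. Any claim that something is new, unique, unknown or untested is made for them only; others in the source may bear on it.

Measured so far in an ADME assay (liver) for metabolic stability, with Liver microsome (Rattus norvegicus) as the target, using microsomes and NADPH, with a stated time of 30 min (on this read-out higher numbers stand for fast clearance and lower numbers for slow clearance), are three compounds:

- Compound 1 (`CC#C[C@H]1CN(S(=O)(=O)c2ccc(N)nc2)CCN1c1ncc(C(C)(O)C(F)(F)F)s1`) gives 87 mL.min-1.g-1
- Compound 2 (`CC#C[C@H]1CN(S(=O)(=O)c2ccc(N)nc2)CCN1c1ccc(C(C)(O)C(F)(F)F)nc1`) gives 31 mL.min-1.g-1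
- Compound 3 (`CC#C[C@H]1CN(S(=O)(=O)c2ccc(N)nc2)CCN1c1ccc(C(O)(COC)C(F)(F)F)cc1`) gives 93 mL.min-1.g-1

Compound 3 (93 mL.min-1.g-1) stands within the scatter of compound 1 (87 mL.min-1.g-1), and both stand clearly apart from compound 2 (31 mL.min-1.g-1). Compound 4 (`CC#C[C@H]1CN(S(=O)(=O)c2ccc(N)nc2)CCN1c1ccc(C(=O)NC)cc1`) has not yet been measured. It differs from compound 3 by one change (a group of 4 heavy atoms (2 carbon, 1 nitrogen, 1 oxygen; no ring) in place of a group of 9 heavy atoms (4 carbon, 2 oxygen, 3 fluorine; no ring), on an aromatic carbon), with methylcarbamoyl entering on an aromatic carbon, para to a large group. Going by the values given here, no measured pair isolates this change, so the data give only a loose guide. Compound 2 (31 mL.min-1.g-1) shows that numbers well under that of compound 3 occur with this shared core. A moderate fall in this assay is therefore expected, with an estimated size (a 2.3-fold lower number from compound 3 to compound 4 (0.37 log units; beyond the scatter)) somewhat beyond the scatter, though the uncertainty is wide. Compound 4 is estimated at 40 mL.min-1.g-1 (range 15 mL.min-1.g-1 to 85 mL.min-1.g-1).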

Compound 4, intrinsic clearance in microsomes: 41 mL.min-1.g-1
Compound 4: middle estimate off by 1.0-fold (0.01 log units), on the low side; measured number inside the range.
By their numbers in this assay, from the lowest: compounds 2 and 4 (each within the scatter of the next); then compounds 1 and 3 (each within the scatter of the next).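

In this assay, the aromatic carbon para to a large group now has its first readable step: methylcarbamoyl in place of the group of 9 heavy atoms gives a 2.3-fold lower number from compound 3 to compound 4 (0.36 log units; beyond the scatter). Going by these compounds alone, this shows that a change at this one place can move the clearance number beyond the scatter, which the earlier compounds could not show, as they differ from one another in more than one place. Nothing measured here bears on why the number falls.

On these data alone, whether the fall belongs to methylcarbamoyl itself or to the loss of the larger group stays open, and a single step cannot separate the two. Also open, as far as these compounds go, is how a primary carboxamide, a dimethylcarbamoyl group, a carboxylic acid or a nitrile on the same aromatic carbon would read in this assay.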